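A few compounds are considered here, and "the series" means these few. Any claim that something is new, unique, unknown or untested is made for them only; others in the source may bear on it.

Three compounds that share one core have been run through a functional assay on MCF7 cells (Homo sapiens) for cytotoxicity, read by MTT assay, with a stated time of 4 days (on this read-out lower numbers stand for stronger inhibition and higher numbers for weaker inhibition), and one more remains to be measured. In this assay compound 1 `C=C1C[C@]23C[C@@]1(O)CC[C@H]2c1ccc(O)c(C)c1[C@@H]3Cn1cc(-c2ccccn2)nn1` gives only a limit, > 20000 nM, and not a number. Compound 1 therefore sits at the limit of > 20000 nM in this assay, at which 1 of the 3 values shown sits. Compound 2 `C=C1C(=O)[C@]23C[C@@]1(O)CC[C@H]2c1ccc(OS(=O)(=O)c2ccc(C)cc2)c(C)c1[C@@H]3Cn1cc(-c2ccccn2)nn1` gives 320 nM in this assay, and compound 3 `C=C1C(=O)[C@]23C[C@@]1(O)CC[C@H]2c1ccc(O)c(C)c1[C@@H]3Cn1cc(-c2ccccn2)nn1` gives 2240 nM. Among the compounds with values here, the single measured step, a 7.0-fold higher number from compound 2 to compound 3 (0.85 log units; beyond the scatter), concerns hydrogen in place of (4-methylphenyl)sulfonyl on an oxygen on an aromatic ring. Compound 4 `C=C1C[C@]23C[C@@]1(O)CC[C@H]2c1ccc(O)c(C)c1[C@@H]3Cn1cc(-c2ccc(C(F)(F)F)cc2)nn1` has not yet been measured; it differs from compound 1 by 4-(trifluoromethyl)phenyl in place of pyridin-2-yl on an aromatic carbon. Within the data shown here, no measured step touches this part of the core, so the step from compound 2 to compound 3 gives no guide to what the exchange of rings on the five-membered aromatic ring with 3 nitrogen will do. Since compound 1 reaches only a limit, compound 4 is expected to give about 20000 nM, somewhere between 5000 nM and 80000 nM, most likely again as a limit. The expected step is a number no higher from compound 1 to compound 4 (the limit leaves the size open).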

Compound 4, half-maximal inhibitory concentration: 12400 nM
Compound 4: the middle estimate sits 1.6-fold (0.21 log units) above what was measured, and the stated range covers the measured number.
By their numbers in this assay, from the lowest: compound 2; then compound 3; then compound 4. At a limit, above all of these: compound 1.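

In this assay, the exchange of rings on the five-membered aromatic ring with 3 nitrogen gives an at least 1.6-fold lower number from compound 1 to compound 4 (0.20 log units; that floor lies within the scatter). Within the data shown here, this is the first look at this position: with 4-(trifluoromethyl)phenyl in place of pyridin-2-yl, compound 4 gives a real number, whereas compound 1 gives only a limit. The true size of the step remains unknown because compound 1 stands at a limit: the limit of > 20000 nM in this assay, at which 1 of the 4 values shown sits.

From the compounds shown here alone, it remains open whether a plain phenyl, or a phenyl ring carrying an amine or a carboxylic acid, would give a lower number at this position. Going by these compounds, it is also open what the same exchange would do on the core of compound 3, which carries a carbonyl that compound 4 lacks.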